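Working notes: methoxy on compound 1

The compounds below may be only part of what the source reports. "The series", "measured", "known", "first", "only" and "open" are said of these compounds alone.

In an ADME assay on L6 cells (Rattus norvegicus) for cytotoxicity (on this read-out higher numbers stand for weaker inhibition and lower numbers for stronger inhibition), compound 1 `CC(C)NC(=N)c1ccc(-c2cc3ccc(C(=N)NC(C)C)cc3o2)cc1` gives > 199000 nM as a limit and no number. Compound 2 `CC(C)NC(=N)c1cccc(-c2cc3ccc(C(=N)NC(C)C)cc3o2)c1` gives > 200000 nM as a limit too. Compound 3 `CC(C)NC(=N)c1ccc(-c2cc3cc(C(=N)NC(C)C)cc(O)c3o2)cc1` also gives > 185000 nM as a limit. Among the compounds with values here, no measured step is therefore available, and compound 1 stands at the limit with the other two. Compound 4 `COc1cc(C(=N)NC(C)C)ccc1-c1cc2ccc(C(=N)NC(C)C)cc2o1` differs from compound 1 by methoxy in place of hydrogen on an aromatic carbon with methoxy in place of hydrogen on an aromatic carbon. A small step toward stronger inhibition, perhaps none beyond the scatter, is expected and estimated as an at least 1.6-fold lower number from compound 1 to compound 4 (0.21 log units; that floor lies within the scatter) in this assay with another limit quite possible. For compound 4 the estimate is 120000 nM with an expected range from 30000 nM to 200000 nM as the working figures.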

Compound 4, half-maximal inhibitory concentration: > 181000 nM
Compound 4: only a limit was reported (the forecaster's own chance of this, stated with the estimate: 50%); middle value at least 1.5-fold (0.17 log units) from the limit.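

Compound 1 and compound 4 are both reported only as limits in this assay, so the step between them cannot be read. The compounds shown leave open whether methoxy in place of hydrogen on an aromatic carbon shifts this read-out at all.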